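The source may report more compounds than this note shows. Statements on the series, on what has been measured and on what is new or still open speak of the compounds shown alone.

The measured compounds are: compound 1 `CC(Sc1nc2nn(C3COC3)cc2c(=O)n1-c1ccccc1)c1ccccc1`, giving 109 nM in an assay on isolated protein for inhibition of aldehyde dehydrogenase 1A1 (Homo sapiens); on this read-out higher numbers stand for weaker inhibition and lower numbers for stronger inhibition; compound 2 `Cn1ncc2c(=O)n(-c3ccccc3)c(SC(C)(C)c3ccccc3)nc21`, giving 1900 nM; and compound 3 `CC(Sc1nc2nn(C3COC3)cc2c(=O)n1-c1ccccc1)c1ccccn1`, giving 68 nM.

Compound 2 stands highest of the three numbers, with compound 1 nearest and compound 3 furthest, both well beyond the scatter. Compound 4 `C[C@H](Sc1nc2c(cnn2C)c(=O)n1-c1ccccc1)c1ccccc1` differs from compound 2 in one place: 1-phenylethyl in place of 1-methyl-1-phenylethyl on a sulfur. Among the measured compounds shown here, no measured step bears directly on this change. For the measured compounds named here, the only measured step, a 1.6-fold lower number from compound 1 to compound 3 (0.20 log units; within the scatter), concerns another position and lies within the scatter. Although it differs from compound 2 elsewhere as well, compound 1 carries 1-phenylethyl on the sulfur, and in this assay compound 1 gives 109 nM, far below the number of compound 2. Compound 4 is therefore expected to move toward that region, a 6.3-fold lower number from compound 2 to compound 4 (0.80 log units; beyond the scatter), though with wide uncertainty since compound 4 is a single stereoisomer. Compound 4 is expected to give 300 nM, within 80 nM to 1200 nM.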

Compound 4, half-maximal inhibitory concentration: 1410 nM
Estimate against measurement, compound 4: 4.7-fold (0.67 log units) below, and the stated range ends below it.
By their numbers in this assay, from the lowest: compounds 3 and 1 (each within the scatter of the next); then compounds 4 and 2 (each within the scatter of the next).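

In this assay, 1-phenylethyl in place of 1-methyl-1-phenylethyl on a sulfur gives a 1.3-fold lower number from compound 2 to compound 4 (0.13 log units; within the scatter). On the core of compound 2, this change alone therefore leaves the number within the scatter, and the much lower number of compound 1, which differs from compound 4 elsewhere as well, cannot be credited to 1-phenylethyl alone. Nothing shown here offers an explanation for this result.

From the compounds shown here alone, what remains open is how the opposite stereoisomer of compound 4 would read. Going by these compounds, it is also open whether a smaller group such as benzyl on the sulfur would shift the number on this core.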